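The compounds below may be only part of what the source reports. "The series", "measured", "known", "first", "only" and "open" are said of these compounds alone.

Compound 1, `CSc1ccc(C)cc1NCC1=NCCN1`: 101%
Compound 2, `CS(=O)(=O)c1ccc(Cl)cc1NCC1=NCCN1`: 91%

In a functional assay for agonist activity at Alpha-1A adrenergic receptor (Homo sapiens) (a higher number here means a larger maximal response, a lower number a smaller maximal response), compound 1 gives 101%, and compound 2 gives 91%. On the numbers compound 2 stands below compound 1, but the gap lies within the scatter, so the two cannot be told apart. Compound 3, `CSc1ccc(Cl)cc1NCC1=NCCN1`, has not been measured. It differs from compound 2 in one place: methylsulfanyl in place of methylsulfonyl on an aromatic carbon. Among the compounds with values here, no measured pair shows the effect of this single change on its own; compound 1 carries methylsulfanyl but also differs from compound 2 in a second place, so its value cannot be read as the change alone. Both measured compounds reach close to the full reference response, which leaves little room for a rise and gives no sign of a loss. The step from compound 2 to compound 3 is therefore expected to be a number 6 percentage points higher from compound 2 to compound 3 (within the scatter), not beyond the scatter. Compound 3 is estimated at 97%, between 80% and 110%.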

Compound 3, largest response reached (reported as maximum), in percent of the reference or control that the assay uses: 82%
Beside the measured number, compound 3's estimate is 15 percentage points above it; the measured number falls inside the stated range.
By their numbers in this assay, from the lowest: compounds 3, 2 and 1 (each within the scatter of the next, the first and the last beyond it).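

Holding the chloro group in place gives the first clean reading of this change: in this assay, putting methylsulfanyl in place of methylsulfonyl on the aromatic carbon para to the chloro group gives a number 9 percentage points lower from compound 2 to compound 3 (within the scatter), so the two groups cannot be told apart at this position. The other single change, chloro in place of methyl on an aromatic carbon, gives a number 19 percentage points lower from compound 1 to compound 3 (beyond the scatter), a modest step and the only one of the two that clears the scatter. No measurement at hand offers an explanation for either step.

The compounds shown leave open how a methoxy group, an amine or a longer chain such as ethylsulfanyl would fare at this position. They also leave open whether the swap between methylsulfanyl and methylsulfonyl would read the same with methyl in place of chloro.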